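Chlorophenyl for Methylphenyl on a Bile Acid Receptor Ligand

The compounds below may be only part of what the source reports. "The series", "measured", "known", "first", "only" and "open" are said of these compounds alone.

Measured so far:
compound 1, `COC(=O)/C=C/c1cccc(N(Cc2ccc(/C=C/c3c(C)cc(C)cc3C)cc2)C(=O)NC(C)C)c1`, 431 nM
compound 2, `COC(=O)/C=C/c1cccc(N(Cc2ccc(-c3cccc(Cl)c3)cc2)C(=O)C(C)C)c1`, 77 nM
compound 3, `COC(=O)/C=C/c1cccc(N(Cc2ccc(-c3ccc(C)cc3)cc2)C(=O)NC(C)C)c1`, 449 nM

Of the compounds shown here, three on a shared core have been tested in an assay on isolated protein with Bile acid receptor (Homo sapiens) as the target; a lower number here means that less compound is needed, a higher number that more compound is needed for the effect. Compound 1 gives 431 nM, compound 2 gives 77 nM and compound 3 gives 449 nM. Compound 3 thus carries the highest number of the three; its nearest neighbour is compound 1, within the scatter, and its furthest is compound 2, whose lower number lies beyond the scatter.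

Compound 4, `COC(=O)/C=C/c1cccc(N(Cc2ccc(-c3cccc(Cl)c3)cc2)C(=O)NC(C)C)c1`, differs from compound 3 by 3-chlorophenyl in place of 4-methylphenyl on an aromatic carbon. For the measured compounds named here, the one measured step that bears on this exchange is a 1.0-fold higher number from compound 1 to compound 3 (0.02 log units; within the scatter), where swapping one aryl piece for another left the number unchanged. Compound 2 also carries a 3-chlorophenyl, but it differs from compound 3 in a second place as well. The value of compound 2, 77 nM, can therefore only hint at a lower number. The expectation for compound 4 is therefore a moderate step down, a 1.8-fold lower number from compound 3 to compound 4 (0.25 log units; within the scatter). Compound 4 is estimated at 250 nM, with a range from 80 nM to 650 nM.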

Compound 4, half-maximal effective concentration: 1400 nM
Compound 4: the middle estimate sits 5.6-fold (0.75 log units) below what was measured; measured number outside the range, above it.
By their numbers in this assay, from the lowest: compound 2; then compounds 1 and 3 (each within the scatter of the next); then compound 4.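

In this assay, the aryl group on this aromatic carbon, para to a large group, proves able to move the number: 3-chlorophenyl in place of 4-methylphenyl gives a 3.1-fold higher number from compound 3 to compound 4 (0.49 log units; beyond the scatter), even though both groups hold the same count of heavy atoms. The exchange of 3-chlorophenyl for 2-(2,4,6-trimethylphenyl)ethenyl gives a similar step, a 3.2-fold higher number from compound 1 to compound 4 (0.51 log units; beyond the scatter), so the earlier aryl exchange that changed nothing does not hold for every aryl group here. The larger step lies at the carbonyl carbon, where isopropylamino in place of isopropyl gives an 18-fold higher number from compound 2 to compound 4 (1.26 log units; beyond the scatter), and this shows that with 3-chlorophenyl in place, that carbonyl substituent weighs more than the aryl exchange.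

No measurement among these results offers an explanation for any of these steps. From the compounds shown here alone, it remains open whether isopropyl on the carbonyl carbon would give a similar step alongside 4-methylphenyl, and how a carboxylic acid in place of the methyl ester would read.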